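The source may report more compounds than this note shows. Statements on the series, on what has been measured and on what is new or still open speak of the compounds shown alone.

Measured in a functional assay on HCT-116 cells (Homo sapiens) for antiproliferative activity, read by MTT assay, with a stated time of 24 h; a lower number here means a stronger inhibitor, a higher number a weaker inhibitor:

- compound 1 `COc1cc(OC)c(-c2coc3cc(OCc4ccc(F)cc4)ccc3c2=O)cc1OC` gives 950 nM
- compound 2 `COc1cc(OC)c(-c2coc3cc(OCc4ccccc4C(F)(F)F)ccc3c2=O)cc1OC` gives 4760 nM
- compound 3 `COc1cc(OC)c(-c2coc3cc(OCc4cccc(F)c4)ccc3c2=O)cc1OC` gives 4920 nM

Two of these numbers sit together at the high end: a 1.0-fold higher number from compound 2 to compound 3 (0.01 log units; within the scatter). Compound 3 therefore belongs to that high pair, and the 4-fluorophenyl group stands apart from it: a 5.2-fold higher number from compound 1 to compound 3 (0.71 log units; beyond the scatter).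

Next is compound 4 `COc1cc(OC)c(-c2coc3cc(OCc4ccccc4Br)ccc3c2=O)cc1OC`, with 2-bromophenyl in place of 3-fluorophenyl on a saturated chain carbon bound to an oxygen on an aromatic ring.

Within the data shown here, no 2-bromophenyl compound has been measured, so the evidence is indirect. The closest measured exchange is between 2-(trifluoromethyl)phenyl and 3-fluorophenyl, which stayed within the scatter: a 1.0-fold higher number from compound 2 to compound 3 (0.01 log units; within the scatter). Among the measured compounds shown here, the only larger steps start from 4-fluorophenyl, which is not involved in this change: a 5.0-fold higher number from compound 1 to compound 2 (0.70 log units; beyond the scatter) and a 5.2-fold higher number from compound 1 to compound 3 (0.71 log units; beyond the scatter).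

No step beyond the scatter is expected in this assay, and the estimate is a 1.1-fold lower number from compound 3 to compound 4 (0.04 log units; within the scatter).

For compound 4 the expected value is 4500 nM, with an estimated range of 1800 nM to 10000 nM.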

Compound 4, half-maximal inhibitory concentration: 4550 nM
Estimate against measurement, compound 4: 1.0-fold (0.00 log units) below; measured number inside the range.
By their numbers in this assay, from the lowest: compound 1; then compounds 4, 2 and 3 (each within the scatter of the next).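

In this assay the 2-bromophenyl group reads with the other two: bromo in place of trifluoromethyl on an aromatic carbon stays within the scatter (a 1.0-fold lower number from compound 2 to compound 4 (0.02 log units; within the scatter)), and so does the exchange with 3-fluorophenyl (a 1.1-fold lower number from compound 3 to compound 4 (0.03 log units; within the scatter)). The separation of the 4-fluorophenyl group therefore holds against a third group (a 4.8-fold higher number from compound 1 to compound 4 (0.68 log units; beyond the scatter)), and among these four compounds, three different substituted phenyl groups on the saturated chain carbon read alike, with only compound 1 going against them. Nothing available here accounts for this grouping.

Open, from the compounds shown here alone, is whether the separation of compound 1 follows the fluorine alone or also extends to a 4-bromophenyl or 4-chlorophenyl group. Also open, going by these compounds, is how an unsubstituted phenyl, or a phenyl carrying an amine or a carboxylic acid, would read in this assay.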